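Amine variation on the shared core: compound 4

This account rests on a few compounds, and the source may have more. Where it says the series, first, only, none or still open, it means among the compounds named here.

Measured so far:
compound 1 `CNc1nc(-c2cc(-c3ccon3)n(Cc3ccccc3F)n2)ncc1F` — 20 nM
compound 2 `Fc1ccccc1Cn1nc(-c2ncc(F)c(N3CCCC3)n2)cc1-c1ccon1` — 83 nM
compound 3 `Fc1ccccc1Cn1nc(-c2ncc(F)c(N3CCC(F)(F)CC3)n2)cc1-c1ccon1` — 250 nM

All three share one core and differ only in the amine on an aromatic carbon. In an assay on a protein complex for activation of soluble guanylate cyclase (Homo sapiens), read by cGMP accumulation, in the presence of a further agent that is not named here (on this read-out lower numbers stand for an effect already at smaller amounts and higher numbers for an effect only at larger amounts of compound), compound 1 gives 20 nM, compound 2 gives 83 nM and compound 3 gives 250 nM. Compound 3 stands highest of the three: a 3.0-fold higher number from compound 2 to compound 3 (0.48 log units; beyond the scatter) and a 13-fold higher number from compound 1 to compound 3 (1.10 log units; beyond the scatter). The other step, a 4.2-fold higher number from compound 1 to compound 2 (0.62 log units; beyond the scatter), is modest.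

Compound 4 `Fc1ccccc1Cn1nc(-c2ncc(F)c(N3CCNCC3)n2)cc1-c1ccon1` has not yet been measured in this assay. It differs from compound 3 as follows: piperazin-1-yl in place of 4,4-difluoropiperidin-1-yl on an aromatic carbon. Going by the values given here, no measured step exchanges a ring for another ring of the same size, so the bearing of the steps is indirect. Each measured step shows that the amine matters, with steps from modest to large; the change to compound 4 keeps a six-membered non-aromatic ring and exchanges the two fluorine atoms for a ring nitrogen. A modest step is therefore expected, more likely downward than upward, but a number indistinguishable within the scatter would not be surprising. Compound 4 is expected to give about 150 nM, within 50 nM to 500 nM, which means an estimated step of a 1.7-fold lower number from compound 3 to compound 4 (0.22 log units; within the scatter).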

Compound 4, half-maximal effective concentration: 120 nM
Compound 4: middle estimate off by 1.3-fold (0.10 log units), on the high side, within the range that was stated.
By their numbers in this assay, from the lowest: compound 1; then compounds 2 and 4 (each within the scatter of the next); then compound 3.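

In this assay, the change from 4,4-difluoropiperidin-1-yl to piperazin-1-yl keeps a six-membered non-aromatic ring and still shifts the number, a 2.1-fold lower number from compound 3 to compound 4 (0.32 log units; beyond the scatter), so ring size alone does not set the value at this position. The ring contents matter here: the exchange swaps the two fluorine atoms for a ring nitrogen, which adds a hydrogen-bond donor and an acceptor to the group. Piperazin-1-yl and pyrrolidin-1-yl cannot be told apart, a 1.4-fold higher number from compound 2 to compound 4 (0.16 log units; within the scatter), while methylamino remains separated from piperazin-1-yl, a 6.0-fold higher number from compound 1 to compound 4 (0.78 log units; beyond the scatter), so compound 1 now stands beyond the scatter from all three ring amines shown.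

Nothing measured here bears on what lies behind these steps. Still open, as far as these compounds go, is how a morpholin-4-yl ring, a 4-methylpiperazin-1-yl ring or a longer chain on the amine, such as ethylamino, would stand against the piperazin-1-yl group of compound 4 and the methylamino group of compound 1.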